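Adding an Amino Group: What Microsomal Stability May Follow

This account rests on a few compounds, and the source may have more. Where it says the series, first, only, none or still open, it means among the compounds named here.

Compound 1 `C[C@H](Nc1nc(N)nc(N)c1C#N)c1cc(=O)n2cc(F)ccc2c1-c1ccccc1`: "not determined" (no result reported)
Compound 2 `C[C@H](Nc1nc(N)nc(N)c1C#N)c1cc(=O)n2cc(F)ccc2c1-c1ccc(F)cc1`: "not determined" (no result reported)
Compound 3 `C[C@H](Nc1ncnc(N)c1C#N)c1cc(=O)n2cc(F)ccc2c1-c1cc(F)cc(F)c1`: 57%

Among the compounds with values here, in an ADME assay on microsomes from liver (Mus musculus), read by LC-MS, using NADPH, with a stated time of 30 min, tested at 1 uM (a lower number here means that less of the compound is left, a higher number that more of the compound is left), compound 3 gives 57%, and this is the only number in the set. Within the data shown here, compound 1 and compound 2 were also entered in this assay: compound 1 gives "not determined" (no result reported) and compound 2 gives "not determined" (no result reported), so compound 3 stands alone: it can be placed neither above nor below any companion, and no step between two measured compounds is available.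

The next compound, compound 4 `C[C@H](Nc1nc(N)nc(N)c1C#N)c1cc(=O)n2cc(F)ccc2c1-c1cc(F)cc(F)c1`, differs from compound 3 in one place: amino in place of hydrogen on an aromatic carbon. Among the measured compounds shown here, since no measured pair shows what an added amino group does in this assay, the data give no direction for this step. The expectation is therefore a step that stays within the usual scatter of this assay, with a wide margin of doubt on both sides.

Compound 4 is expected to show a change of a number 2 percentage points lower from compound 3 to compound 4 (within the scatter) in this assay. This places the estimate for compound 4 at 55%, with a range from 30% to 80%.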

Compound 4, percent of the compound remaining: 90%
Estimate against measurement, compound 4: 35 percentage points below, and the stated range ends below it.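

Hydrogen gives way to amino on the aromatic carbon between two ring nitrogen atoms, and this assay records a number 33 percentage points higher from compound 3 to compound 4 (beyond the scatter) with the rest of the two structures unchanged. This position is therefore not a silent one: a single added heavy atom here is enough to move the read-out past ordinary repeat variation, towards more compound remaining. Nothing measured alongside this result explains why the step is so large.

From the compounds shown here alone, whether another group in the same place, such as a methyl group or a methoxy group, would move the read-out in the same direction remains open. Going by these compounds, compound 1 and compound 2 carry no number, so their steps cannot be read, and it also remains open whether the other aryl groups they carry would change the picture.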